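From pyridin-4-yl to 1H-benzimidazol-1-yl in a cell assay

The source may report more compounds than this note shows. Statements on the series, on what has been measured and on what is new or still open speak of the compounds shown alone.

Measured in a functional assay on PC-3 cells (Homo sapiens) for antiproliferative activity, read by CCK-8 assay, with a stated time of 6 days; a lower number here means a stronger inhibitor, a higher number a weaker inhibitor:
Compound 1 `CCN(c1ccc(C#N)c(Cl)c1)c1cc(-c2ccncc2)ccc1C`: 3580 nM
Compound 2 `N#Cc1ccc(N2CCCc3c(-c4cccnc4)cccc32)cc1C(F)(F)F`: 7970 nM

Compound 1 holds the lower of the two numbers, which makes it the stronger inhibitor of this pair, and its gap to compound 2 lies beyond the usual scatter. Still unmeasured is compound 3 `CCN(c1ccc(C#N)c(Cl)c1)c1cc(-n2cnc3ccccc32)ccc1C`, which keeps the core of compound 1 and changes a single group: 1H-benzimidazol-1-yl in place of pyridin-4-yl on an aromatic carbon.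

Among the compounds with values here, the two measured compounds do not differ in just one place, so no measured step shows how a swap of this kind behaves in this assay. With so little evidence, neither direction can be favoured, and no shift beyond the scatter is expected. The estimated change is small: a 1.1-fold higher number from compound 1 to compound 3 (0.05 log units; within the scatter). The uncertainty is nevertheless large, and the range below is wide to reflect that. For compound 3 the expected value is 4000 nM, within an estimated range from 1000 nM to 15000 nM.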

Compound 3, half-maximal inhibitory concentration: 8160 nM
For compound 3 the middle estimate is 2.0-fold (0.31 log units) below the measured one; the measured number falls inside the stated range.
By their numbers in this assay, from the lowest: compound 1; then compounds 2 and 3 (each within the scatter of the next).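

In this assay, putting 1H-benzimidazol-1-yl in place of pyridin-4-yl on this aromatic carbon, para to a methyl group, gives a 2.3-fold higher number from compound 1 to compound 3 (0.36 log units; beyond the scatter) while the rest of the molecule stays the same. Within the data shown here, this is the first single-place comparison, and it shows that the group at this position affects the result, with the new group making a modestly weaker inhibitor. The swap adds heavy atoms and a second aromatic ring and also changes the ring itself, and no measurement here explains the weaker result or shows which of these differences matters.

Still open, going by these compounds, is whether a simpler group at this position, such as a phenyl ring or an amino group, would give a stronger or a weaker inhibitor than pyridin-4-yl. Among these compounds, with only this one step available, it also remains unknown whether the same swap would shift the number in a similar way on a different core.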